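Replacing 2-fluoro-5-nitrophenyl in compound 3

This account rests on a few compounds, and the source may have more. Where it says the series, first, only, none or still open, it means among the compounds named here.

Measured in a functional assay on DU-145 cells (Homo sapiens) for inhibition, read by trypan blue exclusion, with a stated time of 96 h; on this read-out higher numbers stand for weaker inhibition of growth and lower numbers for stronger inhibition of growth:
- compound 1 `COc1ccccc1/C=C(\C(=O)c1ccc(Br)cc1)S(=O)(=O)c1ccc(C)cc1`: 1000 nM
- compound 2 `COc1ccc(/C=C(\C(=O)c2ccc(Br)cc2)S(=O)(=O)Cc2ccc(F)cc2)cc1`: 25000 nM
- compound 3 `O=C(/C(=C\c1cc([N+](=O)[O-])ccc1F)S(=O)(=O)Cc1ccc(F)cc1)c1ccc(Br)cc1`: > 100000 nM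

Compound 3 stands at > 100000 nM as a limit of the assay and not a number. Compound 4 `COc1ccccc1/C=C(\C(=O)c1ccc(Br)cc1)S(=O)(=O)Cc1ccc(F)cc1` carries 2-methoxyphenyl in place of 2-fluoro-5-nitrophenyl on a double-bonded chain carbon bound to a double-bonded chain carbon on a double-bonded chain carbon bound to a double-bonded chain carbon. Within the data shown here, the one measured step at this place is an at least 4.0-fold higher number from compound 2 to compound 3 (0.60 log units; beyond the scatter), where 2-fluoro-5-nitrophenyl took the place of 4-methoxyphenyl. Compound 1 also carries 2-methoxyphenyl and gives 1000 nM though the rest of its structure differs. Taking these together, the expected step is an at least 16-fold lower number from compound 3 to compound 4 (1.22 log units; beyond the scatter) in this assay, toward a lower number and stronger inhibition of growth. For compound 4 the estimated value is 6000 nM with an expected range of 1500 nM to 25000 nM.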

Compound 4, concentration for 50% growth inhibition: 25000 nM
Estimate against measurement, compound 4: 4.2-fold (0.62 log units) below; low and high end bracket the measured number.
By their numbers in this assay, from the lowest: compound 1; then compounds 2 and 4 (each within the scatter of the next). At a limit, above all of these: compound 3.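

In this assay, the change to 2-methoxyphenyl gives an at least 4.0-fold lower number from compound 3 to compound 4 (0.60 log units; beyond the scatter); this step starts from a limit of the assay, so it is only a minimum. Moving from 4-methoxyphenyl to 2-methoxyphenyl gives no change at the digits printed from compound 2 to compound 4 (within the scatter), so these two groups cannot be told apart at this position. The stronger inhibition of compound 1 therefore does not follow from 2-methoxyphenyl alone, as 4-fluorobenzyl in place of 4-methylphenyl on the sulfonyl sulfur gives a 25-fold higher number from compound 1 to compound 4 (1.40 log units; beyond the scatter).

From the compounds shown here alone, it remains open whether the fluorine or the nitro group of 2-fluoro-5-nitrophenyl accounts for the loss. How a phenyl carrying an amine or a carboxylic acid would behave at this position is also unknown.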